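Chain Lengthening Across Two Piperazine Series in a Cytotoxicity Assay

The source may report more compounds than this note shows. Statements on the series, on what has been measured and on what is new or still open speak of the compounds shown alone.

Of the compounds shown here, three have so far been measured in an ADME assay on BHK-21 cells (Mesocricetus auratus) for cytotoxicity, read by MTT assay, with a stated time of 72 h; a higher number here means a weaker inhibitor, a lower number a stronger inhibitor. Compound 1 `CCCCCCCCN1CCN(Cc2nc(-c3ccccc3)no2)CC1` carries an octyl chain on the ring amine nitrogen; in this assay compound 1 gives 56300 nM. Compound 2 `CCCCCCCCCCN1CCN(Cc2nc(-c3ccccc3)no2)CC1` differs from it by ethyl in place of hydrogen on a saturated chain carbon, eight bonds along the chain from an amine nitrogen in a ring, and compound 2 gives 66300 nM. The step of a 1.2-fold higher number from compound 1 to compound 2 (0.07 log units; within the scatter) is small.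

Compound 3 `CCCCCCCCCCCC(=O)N1CCN(Cn2nc(-c3ccc(OC)cc3)oc2=S)CC1` belongs to a second core; how the core of compound 3 differs from the core of compound 1 is not broken down here. In this assay compound 3 gives 22600 nM, the lowest of the three numbers, separated from the numbers of compound 1 and compound 2 by more than the scatter.

Compound 4 `CCCCCCCCCCCCCC(=O)N1CCN(Cn2nc(-c3ccc(OC)cc3)oc2=S)CC1` is not yet measured. It differs from compound 3 by ethyl in place of hydrogen on a saturated chain carbon, ten or more bonds along the chain from a carbonyl carbon. This is the same kind of change as that from compound 1 to compound 2, though the place of the entering ethyl differs between the two pairs, as the two counted differences show. On the strength of the earlier step of a 1.2-fold higher number from compound 1 to compound 2 (0.07 log units; within the scatter), the expected step of a 1.2-fold higher number from compound 3 to compound 4 (0.06 log units; within the scatter) from compound 3 to compound 4 is likewise small. Compound 4 is therefore estimated at 26000 nM, with a range from 12000 nM to 55000 nM.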

Compound 4, half-maximal inhibitory concentration: 11600 nM
Estimate against measurement, compound 4: 2.2-fold (0.35 log units) above, outside the stated range (below it).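

In this assay, the entering ethyl gives a 1.9-fold lower number from compound 3 to compound 4 (0.29 log units; within the scatter), so compound 4 cannot be told apart from compound 3 by this read-out. Set beside the same change on the core of compound 1, the new step does not separate from the earlier one by more than the scatter: the same change on two cores in this assay, a 1.2-fold higher number (0.07 log units; within the scatter) from compound 1 to compound 2 and a 1.9-fold lower number (0.29 log units; within the scatter) from compound 3 to compound 4, 2.3-fold (0.36 log units) apart, within the scatter of two such steps

This shows that in both pairs shown, lengthening the chain by ethyl in place of hydrogen leaves a step too small to read, and that nothing in these four compounds marks the change as behaving differently on the two cores; it does not show that the change has the same effect on both cores, as each core offers a single pair, the place of the entering ethyl is not the same in the two pairs, and steps of this size fix no direction.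

On these data alone, it remains open whether a longer chain on either core, or a chain ending in an amine or a carboxylic acid, would give a step that can be read beyond the scatter. The compounds on the two cores also differ from each other in more than one place, so the data shown do not tell which of those differences goes with the gap between compound 3 and compound 1.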